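Methoxy in place of trifluoromethyl on the aryl urea

The compounds below may be only part of what the source reports. "The series", "measured", "known", "first", "only" and "open" are said of these compounds alone.

Measured so far:
compound 1, `Cc1cccc(NC(=O)N[C@@H](C)c2ccccc2)c1`, 99%
compound 2, `C[C@@H](NC(=O)Nc1cccc(C(F)(F)F)c1)c1ccccc1`, 82%
compound 3, `C[C@H](NC(=O)Nc1cccc(C(F)(F)F)c1)c1ccccc1`, 94%

Three ureas have been measured in an ADME assay on the whole organism with Oryza sativa as the target, tested at 0.1 uM; a higher number here means a weaker effect of the compound at the concentration tested, a lower number a stronger effect. Compound 3 stands second highest of the three numbers: its nearest neighbour is compound 1, from which it is reached by a number 5 percentage points lower from compound 1 to compound 3 (within the scatter), and its furthest is compound 2, from which it is reached by a number 12 percentage points higher from compound 2 to compound 3 (beyond the scatter). The larger of these two steps rests on (the fact that compounds 2 and 3 differ only in the configuration as drawn), while the swap of a group on the aromatic carbon left the number where it was.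

Compound 4, `COc1cccc(NC(=O)N[C@@H](C)c2ccccc2)c1`, has not yet been measured. It differs from compound 3 by methoxy in place of trifluoromethyl on an aromatic carbon. For the measured compounds named here, the only measured step that bears on this change is the one from compound 1 to compound 3, which exchanged a group on the same aromatic carbon and stayed within the scatter. A change of similar size is therefore expected here, with no step beyond the scatter in either direction. Compound 4 is thus expected to give 95%, between 84% and 100%, an estimated step of a number 1 percentage points higher from compound 3 to compound 4 (within the scatter).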

Compound 4, a percentage reported as activity, at one concentration (the size of the read-out at that concentration, not a potency): 101%
Compound 4: the middle estimate sits 6 percentage points below what was measured, and the stated range ends below it.
By their numbers in this assay, from the lowest: compound 2; then compounds 3, 1 and 4 (each within the scatter of the next).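

Methoxy on this aromatic carbon gives a reading in this assay that cannot be told apart from those of the two groups seen there before, with a number 7 percentage points higher from compound 3 to compound 4 (within the scatter) and a number 2 percentage points higher from compound 1 to compound 4 (within the scatter). So three different groups have now stood at this position in compounds 1, 3 and 4 without separating, and the hydrogen-bond acceptor that enters with methoxy, absent from trifluoromethyl, leaves the number inside the scatter. Nothing at hand accounts for why these groups read alike.

From the compounds shown here alone, it remains open whether an amine or a carboxylic acid on this same carbon would give a number beyond the scatter. Going by these compounds, it also remains open whether the configuration step, a number 12 percentage points higher from compound 2 to compound 3 (beyond the scatter), would recur with methoxy in place of trifluoromethyl.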